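The source may report more compounds than this note shows. Statements on the series, on what has been measured and on what is new or still open speak of the compounds shown alone.

Measured compounds:

Compound 1, `Cc1nc(N(C)c2ccc([Se]C#N)c(Cl)c2)c2ccccc2n1`: 12 nM
Compound 2, `COc1ccc(N(C)c2nc(C)nc3ccccc23)cc1C(=O)OCCCCC[Se]C#N`: 714 nM
Compound 3, `Cc1nc(N(C)c2ccc([Se]C#N)c(F)c2)c2ccccc2n1`: 13 nM

In a functional assay on LoVo cells (Homo sapiens) for inhibition, read by MTT assay, with a stated time of 48 h (on this read-out higher numbers stand for weaker inhibition and lower numbers for stronger inhibition), compound 1 gives the lowest of the three numbers. Among the compounds with values here, compound 3 stands next to it, and the one measured step, a 1.1-fold higher number from compound 1 to compound 3 (0.03 log units; within the scatter), shows that this halogen swap changes nothing beyond the scatter. Compound 2, with its different arrangement of the selenocyanate group on a chain, gives 714 nM, a number far above that of compound 1.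

The compound not yet measured is compound 4, `C[Se]c1ccc(N(C)c2nc(C)nc3ccccc23)cc1Cl`. Compared with compound 1 the change is methyl in place of cyano on a selenium. Within the data shown here, no measured step concerns this position: the only step in hand, from compound 1 to compound 3, touches a ring halogen and is within the scatter, so it says nothing about what happens on the selenium. Among the measured compounds shown here, compound 2 shows only that a compound carrying the selenocyanate group elsewhere in the molecule gives a much higher number, which is not the same change. For the measured compounds named here, with no step to lean on, the size of the shift in this assay for compound 4 is open; a moderately higher number than compound 1 is expected, as a 5.0-fold higher number from compound 1 to compound 4 (0.70 log units; beyond the scatter). Compound 4 is therefore estimated at 60 nM, with a range from 10 nM to 500 nM.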

Compound 4, half-maximal inhibitory concentration: 3 nM
Compound 4: the middle estimate sits 20-fold (1.30 log units) above what was measured, and the stated range ends above it.
By their numbers in this assay, from the lowest: compound 4; then compounds 1 and 3 (each within the scatter of the next); then compound 2.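

In this assay, within the data shown here, methyl in place of cyano on a selenium gives a 4.0-fold lower number from compound 1 to compound 4 (0.60 log units; beyond the scatter) and so provides the first direct reading at this position, one that runs towards a lower number. For this pair, the cyano group, with its triple bond and its hydrogen-bond acceptor, is therefore not needed for a low number on the shared core, something neither the step at the ring halogen nor compound 2, which differs from compound 1 in more than one place, could show. Nothing available explains the direction or the size of this step.

The compounds shown leave open whether a longer chain on the selenium, such as an ethyl or propyl group, or a group carrying an amine or a carboxylic acid there, would keep the number as low as methyl does. They also leave open whether the same change would give a step of similar size in the fluoro compound, compound 3, and whether a methylthio group could stand in for the methyl on selenium.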